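Notes: 4-bromobenzyl to 4-chlorobenzyl

The compounds below may be only part of what the source reports. "The series", "measured", "known", "first", "only" and "open" are said of these compounds alone.

Measured so far in an ADME assay on HEK293 cells (Homo sapiens) for cytotoxicity, read by MTT assay, with a stated time of 24 h; on this read-out lower numbers stand for stronger inhibition and higher numbers for weaker inhibition:
- compound 1 `CN(C)CCCNc1nc2cc([N+](=O)[O-])ccc2nc1NCc1ccccc1`: 2.74 ug/mL
- compound 2 `CN(C)CCCNc1nc2cc([N+](=O)[O-])ccc2nc1NCc1ccc(Br)cc1`: 9.63 ug/mL

Going by the values given here, of the two numbers in hand, compound 2 has the higher, at 9.63 ug/mL, and compound 1 is its only neighbour. The next compound is compound 3 `CN(C)CCCNc1nc2cc([N+](=O)[O-])ccc2nc1NCc1ccc(Cl)cc1`, which has chloro in place of bromo on an aromatic carbon, para to a large group: chloro in place of bromo on an aromatic carbon.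

Among the compounds with values here, one measured step bears on this change, the bromo in place of hydrogen at that same place, a 3.5-fold higher number from compound 1 to compound 2 (0.55 log units; beyond the scatter). Within the data shown here, that step is modest, and it is the only evidence, since no chloro compound has yet been measured. Compound 3 is therefore expected to fall between the two measured compounds, giving back part of that step but not all of it. The expected step in this assay is small and toward a lower number, a 1.5-fold lower number from compound 2 to compound 3 (0.17 log units; within the scatter), and it may not clear the scatter. For compound 3 the estimated value is 6.5 ug/mL, with an expected range of 3.2 ug/mL to 13 ug/mL.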

Compound 3, half-maximal inhibitory concentration: 10.7 ug/mL
Beside the measured number, compound 3's estimate is 1.6-fold (0.22 log units) below it; low and high end bracket the measured number.
By their numbers in this assay, from the lowest: compound 1; then compounds 2 and 3 (each within the scatter of the next).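

Notes on the 4-bromobenzyl to 4-chlorobenzyl change: in this assay, the two halogens at this place, para to a large group, are not told apart (a 1.1-fold higher number from compound 2 to compound 3 (0.05 log units; within the scatter)), so exchanging bromo for chloro leaves the number within the scatter. The shift away from the unsubstituted benzyl compound now appears with a second halogen (a 3.9-fold higher number from compound 1 to compound 3 (0.59 log units; beyond the scatter)), which is beyond the scatter and of the same order as the bromo step (a 3.5-fold higher number from compound 1 to compound 2 (0.55 log units; beyond the scatter)), so among these three compounds the change that registers is halogen in place of hydrogen, and the identity of the halogen does not register, with neither compound 2 nor compound 3 going against this reading. Nothing among the data shown accounts for this outcome.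

Still open, from the compounds shown here alone, is whether the shift is particular to chloro and bromo or also follows from fluoro, methyl, methoxy or an amine at the same place. Also open, going by these compounds, is whether chloro elsewhere on the same ring, or a longer chain in place of the benzyl link, would give a similar number.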